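The compounds below may be only part of what the source reports. "The series", "measured", "known", "first", "only" and "open" are said of these compounds alone.

Compound 1, `CC(=O)N1N=C(c2ccc3ccccc3c2)OC1c1ccccc1`, gives the highest of the two numbers recorded in a functional assay on B16-F10 cells (Mus musculus) for antiproliferative activity, read by MTT assay, with a stated time of 48 h (a higher number here means a weaker inhibitor, a lower number a stronger inhibitor), at 2.57 ug/mL. Among the measured compounds shown here, the only other measured compound, compound 2, `CC(=O)N1N=C(c2ccc3ccccc3c2)OC1c1cccc(F)c1`, gives 1.61 ug/mL in this assay, and the step of a 1.6-fold lower number from compound 1 to compound 2 (0.20 log units; within the scatter) is within the scatter.

Compound 3, `CC(=O)N1N=C(c2ccc3ccccc3c2)OC1c1ccccn1`, has not been measured in this assay. It differs from compound 1 in one place: pyridin-2-yl in place of phenyl on a saturated ring carbon. For the measured compounds named here, the single measured step, from compound 1 to compound 2, changes a different group and was within the scatter; no measured step involves an exchange of the ring that sits on the saturated ring carbon, so nothing in the data points to a shift in either direction. Compound 3 is therefore expected to give a number close to that of compound 1, with the step of a 1.0-fold lower number from compound 1 to compound 3 (0.01 log units; within the scatter) expected to stay within the scatter. The estimate for compound 3 in this assay is 2.5 ug/mL, with a range from 1 ug/mL to 6.5 ug/mL.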

Compound 3, half-maximal inhibitory concentration: 7.18 ug/mL
Compound 3: the middle estimate sits 2.9-fold (0.46 log units) below what was measured; measured number above the stated range.
By their numbers in this assay, from the lowest: compounds 2 and 1 (each within the scatter of the next); then compound 3.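

Pyridin-2-yl in place of phenyl on the saturated ring carbon is the first change here to move the number in this assay beyond the scatter, with a 2.8-fold higher number from compound 1 to compound 3 (0.45 log units; beyond the scatter) marking a modest loss. The same exchange measured against the 3-fluorophenyl group gives a 4.5-fold higher number from compound 2 to compound 3 (0.65 log units; beyond the scatter) and leaves compound 3 as the weakest of the three, so this position responds to a nitrogen entering the aromatic ring, whereas the step from compound 1 to the fluoro compound stayed within the scatter. Nothing measured here accounts for this loss.

The compounds shown leave open whether pyridin-3-yl or pyridin-4-yl would give the same step, and so whether the placing of the nitrogen in the aromatic ring matters or only its presence. Also open, as far as these compounds go, is whether an amine or a methoxy group on the phenyl ring would move the number beyond the scatter, and in which direction.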